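Extra methoxy on an inactive phenol

A few compounds are considered here, and "the series" means these few. Any claim that something is new, unique, unknown or untested is made for them only; others in the source may bear on it.

Measured in a functional assay on HepG2 cells (Homo sapiens) for cytotoxicity, read by MTT assay; on this read-out lower numbers stand for stronger inhibition and higher numbers for weaker inhibition:
- compound 1 `COc1c(O)ccc(C=O)c1OC` gives > 100000 nM
- compound 2 `COc1c(O)ccc(/C=C\Cc2ccc(O)cc2)c1OC` gives > 100000 nM

Compound 2 stands at > 100000 nM, which is a limit of the assay and not a number. Compound 1 gives > 100000 nM, which is also a limit. The data therefore show only (the limit of > 100000 nM in this assay, at which 2 of the 2 values shown sit).

Compound 3 `COc1cc(C/C=C\c2ccc(O)c(OC)c2OC)ccc1O` is compound 2 with one structural change: methoxy in place of hydrogen on an aromatic carbon. This is methoxy in place of hydrogen on an aromatic carbon, ortho to a hydroxy group.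

Going by the values given here, no measured pair shows what this change does in this assay. With nothing to suggest a direction, no step beyond the usual scatter is expected. The expected change is a number no higher from compound 2 to compound 3 (the limit leaves the size open). The expected value for compound 3 is 100000 nM, with an estimated range from 40000 nM to 200000 nM.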

Compound 3, half-maximal inhibitory concentration: > 100000 nM
Compound 3: only a limit was reported (the forecaster's own chance of this, stated with the estimate: 75%); the middle value lies on the limit itself.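

The step from compound 2 to compound 3 cannot be read, since both compounds sit at a limit of the assay and not at a number: the limit of > 100000 nM in this assay, at which 3 of the 3 values shown sit.

On these data alone, whether adding the methoxy changes the inhibition at all, and in which direction, stays open.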